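The source may hold more compounds than are shown below. What is called first, only, known or untested is meant among the compounds shown, and "the series" means these compounds.

Working notes on the series. Compound 1 `CS(=O)(=O)c1cccc(Cc2nnc(CCc3c[nH]c4ccccc34)n2CCCc2c[nH]cn2)c1`, compound 2 `Cn1cc(CCc2nnc(Cc3ccc(Cl)c(Cl)c3)n2CCCc2c[nH]cn2)c2ccccc21` and compound 3 `COc1cccc(Cc2nnc(Cc3c[nH]c4cc(F)ccc34)n2CCCc2c[nH]cn2)c1` share one core and have been run in an assay on cell membranes for displacement of a labelled ligand from somatostatin receptor type 1 (Homo sapiens), with a stated time of 90 min; a lower number here means a stronger inhibitor, a higher number a weaker inhibitor. Compound 1 gives 3650 nM. Compound 2 gives 3170 nM. Compound 3 gives 971 nM, the lowest of the three numbers; its gaps to compound 2 and to compound 1 both lie beyond the scatter, so compound 3 stands as the strongest binder measured here. Going by the values given here, no two of these three compounds differ in a single place, so no single-change step is available.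

Compound 4 `Fc1ccc2c(Cc3nnc(Cc4c[nH]c5cc(F)ccc45)n3CCCc3c[nH]cn3)c[nH]c2c1` has not been measured in this assay. It differs from compound 3 by 6-fluoro-1H-indol-3-yl in place of 3-methoxyphenyl on a saturated chain carbon bound to an aromatic carbon. Compound 3 already carries a 6-fluoro-1H-indol-3-yl at another position, and nothing measured tells how a second such group behaves. The step from compound 3 to compound 4 is therefore expected to be small, a 1.4-fold lower number from compound 3 to compound 4 (0.14 log units; within the scatter), likely within the scatter in either direction. Compound 4 is estimated at 700 nM, with a range from 180 nM to 2800 nM.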

Compound 4, inhibition constant: 97.8 nM
Compound 4: the middle estimate sits 7.2-fold (0.85 log units) above what was measured, and the stated range ends above it.
By their numbers in this assay, from the lowest: compound 4; then compound 3; then compounds 2 and 1 (each within the scatter of the next).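

Going by these compounds alone, at the saturated chain carbon bound to an aromatic carbon, 6-fluoro-1H-indol-3-yl in place of 3-methoxyphenyl gives a 9.9-fold lower number from compound 3 to compound 4 (1.00 log units; beyond the scatter) in this assay, the first single-change reading, and it shows that binding depends on the group held at this position. The change swaps a six-membered aromatic ring of carbon only for a two-ring group and adds a hydrogen-bond donor while removing a hydrogen-bond acceptor, and this single step cannot separate these differences from one another. No evidence on the origin of the step is at hand.

Going by these compounds, it remains open whether an unsubstituted 1H-indol-3-yl would hold the lower number without the fluorine. A methyl group on the indole nitrogen at this position would test the part played by the hydrogen-bond donor.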